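Swapping the sulfur substituent in a series sitting at the limit

The compounds below may be only part of what the source reports. "The series", "measured", "known", "first", "only" and "open" are said of these compounds alone.

In a functional assay on the whole organism with Mus musculus as the target (a higher number here means that more compound is needed for the effect, a lower number that less compound is needed), compound 3 `Cc1c(C)c2c(c(C)c1N)CC(C)(CSc1ccc(O)cc1)O2` gives only a limit of > 50 mg/kg and no number. Compound 1 `Cc1c(C)c2c(c(N)c1N)CC(C)(C)O2` also gives only a limit of > 50 mg/kg in this read-out. The data so far are marked by the limit of > 50 mg/kg in this assay, at which 2 of the 3 values shown sit, as their main feature. For the measured compounds named here, compound 2 `CC(C)=Cc1c(C)c(N)c(C)c2c1OC(C)(C)C2` is the only one with a number, at 21.9 mg/kg in this assay so far.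

Compound 4 `Cc1c(C)c2c(c(C)c1N)CC(C)(CSCCC(=O)O)O2` carries 2-carboxyethyl in place of 4-hydroxyphenyl on a sulfur, with 2-carboxyethyl in place of 4-hydroxyphenyl on a sulfur as the full count of the change. Going by the values given here, no measured pair isolates this change, so the data give no size for it. No step beyond the scatter is expected in this assay and no direction is favoured. Compound 3 at > 50 mg/kg is a limit and the sole anchor for that expectation. The estimated step that the limit leaves unreadable from compound 3 to compound 4 is therefore small, and another limit is the likeliest report. For compound 4 the estimate is 60 mg/kg with an expected range of 25 mg/kg to 150 mg/kg in this read-out.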

Compound 4, dose for 50% inhibition: 43 mg/kg
Estimate against measurement, compound 4: 1.4-fold (0.14 log units) above, within the range that was stated.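

In this assay, for the compounds shown here, compound 4, with 2-carboxyethyl on a sulfur, gives 43 mg/kg, a real number at a place that had so far given none. Compound 3, with 4-hydroxyphenyl on that sulfur, stands at > 50 mg/kg, which is a limit. The change gives an at least 1.1-fold lower number from compound 3 to compound 4 (0.06 log units; that floor lies within the scatter), so this position accepts a chain without a ring and still yields a readable value, but the data show no gain that clearly exceeds the scatter.

The true size of the step stays unreadable, and the series is still marked by a limit: the limit of > 50 mg/kg in this assay, at which 2 of the 4 values shown sit.

Open, on these data alone, is whether an amine in place of the carboxylic acid, or a longer chain on the sulfur, would move the number beyond the scatter.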